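The source may hold more compounds than are shown below. What is called first, only, known or untested is meant among the compounds shown, and "the series" means these compounds.

In an assay on HEK293 cells for inhibition of acid ceramidase (Homo sapiens), read by fluorescence, with stated times of 10 min and 3 h (a higher number here means a weaker inhibitor, a lower number a stronger inhibitor), three compounds built on a shared core have been measured. Compound 1 `O=C(NCCCCc1ccccc1)n1c(=O)oc2cc(C3CCOCC3)ccc21` gives 68 nM. Compound 2 `CC(C)CN1CCC(c2ccc3c(c2)oc(=O)n3C(=O)NCCCCc2ccccc2)CC1` gives 120 nM, and compound 3 `CN1CCN(c2ccc3c(c2)oc(=O)n3C(=O)NCCCCc2ccccc2)CC1` gives 116 nM. Compound 3 thus stands second highest of the three numbers, with compound 2 nearest and compound 1 furthest, and every step among them lies within the scatter: a 1.8-fold higher number from compound 1 to compound 2 (0.25 log units; within the scatter), a 1.7-fold higher number from compound 1 to compound 3 (0.23 log units; within the scatter) and a 1.0-fold lower number from compound 2 to compound 3 (0.01 log units; within the scatter). Compound 4 `CC(C)CN1CCN(c2ccc3c(c2)oc(=O)n3C(=O)NCCCCc2ccccc2)CC1` has not yet been measured in this assay. It differs from compound 3 by isopropyl in place of hydrogen on a saturated chain carbon bound to an amine nitrogen in a ring. Among the compounds with values here, the steps that bear on this change are the three already seen, in which the group on the aromatic carbon was exchanged without moving the number beyond the scatter. Compound 4 is therefore expected to stay close to compound 3, with an estimated step of a 1.0-fold higher number from compound 3 to compound 4 (0.01 log units; within the scatter) and no direction beyond the scatter, because compound 2 with its isobutyl on the ring amine gives 120 nM. The estimate for compound 4 in this assay is 120 nM, within a range from 55 nM to 260 nM.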

Compound 4, half-maximal inhibitory concentration: 127 nM
Estimate against measurement, compound 4: 1.1-fold (0.02 log units) below; the measured number falls inside the stated range.
By their numbers in this assay, from the lowest: compounds 1, 3, 2 and 4 (each within the scatter of the next).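

In this assay, isopropyl in place of hydrogen on a saturated chain carbon bound to an amine nitrogen in a ring, which turns 4-methylpiperazin-1-yl into 4-isobutylpiperazin-1-yl, gives a 1.1-fold higher number from compound 3 to compound 4 (0.04 log units; within the scatter) and so leaves the number within the scatter at this position. With 4-isobutylpiperazin-1-yl in place, the exchanges of the other groups give a 1.1-fold higher number from compound 2 to compound 4 (0.02 log units; within the scatter) and a 1.9-fold higher number from compound 1 to compound 4 (0.27 log units; within the scatter), so all four compounds remain within the scatter of their neighbours in the order of their numbers. Nothing available accounts for this result.

From the compounds shown here alone, whether a carboxylic acid or a benzyl group on this ring amine would move the number beyond the scatter remains open. So does the number for a ring amine carrying only hydrogen.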